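The source may hold more compounds than are shown below. What is called first, only, known or untested is meant among the compounds shown, and "the series" means these compounds.

Compound 1 `O=c1c2ccccc2c(-c2cccnc2)nn1Cc1ccccc1` gives 97% in an assay on isolated protein (Oryctolagus cuniculus) with Thromboxane-A synthase (Homo sapiens) as the target, tested at 1 uM (a lower number here means less inhibition, a higher number more inhibition at the concentration tested (going by the name of the read-out)), and compound 2 `O=c1c2ccccc2c(-c2cccnc2)nn1Cc1cccc(Cl)c1` gives 95%; the step of a number 2 percentage points lower from compound 1 to compound 2 (within the scatter) is the only measured one between two compounds that differ in a single place. Compound 3 `O=c1c2ccccc2c(-c2cccnc2)nn1CCCCSc1ncccn1` gives 96% and stands second highest of the three numbers, with compound 1 nearest and compound 2 furthest, both gaps within the scatter. Compound 4 `NCCn1nc(-c2cccnc2)c2ccccc2c1=O` differs from compound 3 by amino in place of 2-((pyrimidin-2-yl)sulfanyl)ethyl on a saturated chain carbon, two bonds along the chain from an aromatic nitrogen. For the measured compounds named here, the one measured step concerns a chloro for a hydrogen on an aromatic carbon and says nothing about shortening the chain, so no expectation beyond the scatter can be drawn from it in this assay. As an estimate, compound 4 is expected to give 85%, between 55% and 98%, an expected step of a number 11 percentage points lower from compound 3 to compound 4 (beyond the scatter).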

Compound 4, a percentage reported as inhibition, at one concentration (the size of the read-out at that concentration, not a potency): 29%
For compound 4 the middle estimate is 56 percentage points above the measured one, and the stated range ends above it.
By their numbers in this assay, from the lowest: compound 4; then compounds 2, 3 and 1 (each within the scatter of the next).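

The group on this chain is not free to change, even though the three earlier compounds all gave values within the scatter of one another. In this assay amino in place of 2-((pyrimidin-2-yl)sulfanyl)ethyl gives (a number 67 percentage points lower from compound 3 to compound 4 (beyond the scatter)), while aminomethyl gives (a number 66 percentage points lower from compound 2 to compound 4 (beyond the scatter)) in place of 3-chlorophenyl and (a number 68 percentage points lower from compound 1 to compound 4 (beyond the scatter)) in place of phenyl. No measurement at hand explains these large steps.

From the compounds shown here alone, whether the shorter chain, the missing ring or the amino group itself matters stays open. A longer chain ending in amino, or a hydroxyl in place of amino, would help to separate these.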